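A few compounds are considered here, and "the series" means these few. Any claim that something is new, unique, unknown or untested is made for them only; others in the source may bear on it.

In an ADME assay on Vero cells (Chlorocebus sabaeus) for cytotoxicity, read by MTT assay, with a stated time of 72 h (on this read-out higher numbers stand for weaker inhibition and lower numbers for stronger inhibition), three compounds sharing one core have been measured. Compound 2 (`COc1ccc(-c2ccnc(Nc3ccc(C(=O)O)cc3)n2)cc1`) gives > 100000 nM, which is a limit of the assay and not a number.

Compound 1 (`COc1ccc(-c2ccnc(Nc3cccc(S(N)(=O)=O)c3)n2)cc1`) gives 1100 nM, and compound 3 (`COc1ccc(-c2ccnc(Nc3cccc(C(N)=O)c3)n2)cc1`) gives 2700 nM. Among the compounds with values here, the one measured step between these compounds is a 2.5-fold higher number from compound 1 to compound 3 (0.39 log units; beyond the scatter), where carbamoyl takes the place of sulfamoyl on an aromatic carbon.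

Compound 4 (`COc1ccc(-c2ccnc(Nc3ccc(C(N)=O)cc3)n2)cc1`) has not yet been measured. It differs from compound 2 by amino in place of hydroxy on a carbonyl carbon, which turns carboxy into carbamoyl: amino in place of hydroxy on a carbonyl carbon.

Within the data shown here, no measured step starts from carboxy, so the size of this change cannot be read directly from the data. The modest step above shows only that exchanging sulfamoyl for carbamoyl moved the number by a small amount. The closest guide is compound 3, which also carries carbamoyl and gives 2700 nM. A large move to a lower number, meaning stronger inhibition, is therefore expected in this assay.

The expected size of the change is an at least 25-fold lower number from compound 2 to compound 4 (1.39 log units; beyond the scatter). For compound 4 the estimate is 4000 nM. The expected range for compound 4 runs from 1000 nM to 30000 nM.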

Compound 4, half-maximal inhibitory concentration: 5400 nM
For compound 4 the middle estimate is 1.4-fold (0.13 log units) below the measured one; the measured number falls inside the stated range.
By their numbers in this assay, from the lowest: compound 1; then compounds 3 and 4 (each within the scatter of the next). At a limit, above all of these: compound 2.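

In this assay, within the data shown here, amino in place of hydroxy on a carbonyl carbon gives an at least 18-fold lower number from compound 2 to compound 4 (1.26 log units; beyond the scatter), a large change and the first measured step that starts from carboxy. Among these compounds, the earlier compounds showed only a modest move between sulfamoyl and carbamoyl, so this step is the first sign of how much the carboxy group itself can count against carbamoyl on this core. Its size is a lower bound and not an exact figure, as one end of the step is a limit of the assay and not a number: the limit of > 100000 nM in this assay, at which 1 of the 4 values shown sits.

Compound 4 gives 5400 nM and compound 3, the other carbamoyl compound, gives 2700 nM, two values within the scatter of each other, so the two compounds that carry carbamoyl read alike in this assay.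

The compounds shown leave open how far the true value of compound 2 lies beyond its limit, and so how large the step really is. Also open, on these data alone, is whether a methyl ester on the same carbonyl carbon would read like compound 2 or like compound 4.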